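The source may hold more compounds than are shown below. What is called first, only, known or untested is meant among the compounds shown, and "the series" means these compounds.

Measured in a functional assay on HCT-116 cells (Homo sapiens) for antiproliferative activity, read by MTT assay, with a stated time of 72 h; on this read-out higher numbers stand for weaker inhibition and lower numbers for stronger inhibition:
- Compound 1 `C/C=C1/[C@H](O[C@@H]2O[C@H](CO)[C@@H](O)[C@H](O)[C@H]2O)OC=C(C(=O)OC)[C@H]1CC(=O)OCCC1CCCCC1`: 13700 nM
- Compound 2 `C/C=C1/[C@H](O[C@@H]2O[C@H](CO)[C@@H](O)[C@H](O)[C@H]2O)OC=C(C(=O)OC)[C@H]1CC(=O)OCCc1ccc(O)c(O)c1`: 182000 nM

Compound 2, at 182000 nM, has the higher of the two numbers, so it is the weaker inhibitor of the pair. Compound 3 `C/C=C1/[C@H](O[C@@H]2O[C@H](CO)[C@@H](O)[C@H](O)[C@H]2O)OC=C(C(=O)OC)[C@H]1CC(=O)OCCC(C)C` carries isopropyl in place of 3,4-dihydroxyphenyl on a saturated chain carbon, two bonds along the chain from an oxygen next to a carbonyl group. Going by the values given here, one measured step bears on this change, at the same place: a 13-fold higher number from compound 1 to compound 2 (1.12 log units; beyond the scatter), a large step beyond the scatter, made by bringing in 3,4-dihydroxyphenyl for cyclohexyl. Removing that group again should therefore lower the number in this assay, though perhaps by less, since isopropyl is not cyclohexyl. The expected step is a 6.1-fold lower number from compound 2 to compound 3 (0.78 log units; beyond the scatter). For compound 3 the estimated value is 30000 nM, within an expected range of 12000 nM to 80000 nM.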

Compound 3, half-maximal inhibitory concentration: 26700 nM
The estimate for compound 3 lay 1.1-fold (0.05 log units) above the measured number; the measured number falls inside the stated range.
By their numbers in this assay, from the lowest: compounds 1 and 3 (each within the scatter of the next); then compound 2.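

Isopropyl in place of 3,4-dihydroxyphenyl gives a 6.8-fold lower number from compound 2 to compound 3 (0.83 log units; beyond the scatter) in this assay, so a second group without the aromatic ring also stands apart from compound 2. Isopropyl in place of cyclohexyl gives a 1.9-fold higher number from compound 1 to compound 3 (0.29 log units; within the scatter) in this assay, so at this position a ring is not needed to reach the number of compound 1. Nothing available here explains these differences. Still open, as far as these compounds go, is whether a plain phenyl, without the two hydroxyl groups, would sit with compound 2 or with compound 1 and compound 3, and what an amine at this place would do.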